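Chloro to Bromo: Expecting a Second Lipophilicity Step

The source may report more compounds than this note shows. Statements on the series, on what has been measured and on what is new or still open speak of the compounds shown alone.

Compound 1, `CC(C)[C@@H]1CC[C@@H](C)C[C@H]1OC(=O)c1cccc(Cl)c1`, gives 5.34 in a physicochemical assay for lipophilicity, measured as octanol-water partition; on this read-out lower numbers stand for lower lipophilicity and higher numbers for higher lipophilicity.
Compound 2, `CC(C)[C@@H]1CC[C@@H](C)C[C@H]1OC(=O)c1ccccc1Cl`, gives 5.34 in this assay.
Compound 3, `CC(C)[C@@H]1CC[C@@H](C)C[C@H]1OC(=O)c1cccc(Br)c1`, gives 5.61 in this assay.

Compound 1 and compound 2 are built from the same atoms joined differently; the difference between the two cores is not broken down here. In this assay compound 2 stands level with compound 1, and the two together hold the lowest numbers of the three, with compound 3 a little higher.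

One change has already been measured. Going from compound 1 to compound 3 makes (bromo in place of chloro on an aromatic carbon), and the step in this assay is a number 0.27 log units higher from compound 1 to compound 3 (within the scatter). Compound 4, `CC(C)[C@@H]1CC[C@@H](C)C[C@H]1OC(=O)c1ccccc1Br`, has not yet been measured. It relates to compound 2 as compound 3 relates to compound 1: bromo in place of chloro on an aromatic carbon. This is the same kind of change, though not the same in every respect: in compound 3 the bromo sits meta to a large group, in compound 4 it sits ortho to a large group.

Going by the values given here, with only a single measured example of this change, the expectation for compound 4 rests on it. In this assay the step from compound 2 to compound 4 is expected to be a number 0.27 log units higher from compound 2 to compound 4 (within the scatter), because the earlier step was a number 0.27 log units higher from compound 1 to compound 3 (within the scatter). Compound 4 is therefore estimated at 5.61, most likely between 5.3 and 5.92.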

Compound 4, partition coefficient: 5.61
The estimate for compound 4 equals the measured number at the digits printed; measured number inside the range.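

In this assay the change from chloro to bromo gives a step that reads a number 0.27 log units higher from compound 2 to compound 4 (within the scatter) on the core of compound 2, and this matches at the digits printed the earlier step, a number 0.27 log units higher from compound 1 to compound 3 (within the scatter) on the core of compound 1. Across these two cores, then, the change carried over at the same size, even with the bromo ortho to a large group in compound 4, but two pairs are a small base, and each step lies within the usual scatter of repeated measurements, so neither can be told apart from that scatter on its own. The agreement shows that the earlier step was a fair guide here, yet it does not show a rule for other cores, and nothing available explains why the two steps match in size.

The compounds shown leave open whether a swap to iodo or to fluoro on the same aromatic carbon would follow the same pattern in this series. They also leave open what an amine or a carboxylic acid at that place would do to the partition number, and whether the chloro-to-bromo step would keep its size on a core without the ester.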